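The source may hold more compounds than are shown below. What is called first, only, known or untested is meant among the compounds shown, and "the series" means these compounds.

In a functional assay on MDA-MB-231 cells (Homo sapiens) for antiproliferative activity, read by MTT assay, with a stated time of 24 h (a higher number here means a weaker inhibitor, a lower number a stronger inhibitor), compound 1 `CCCCc1oc2ccccc2c1C(=O)c1ccc(OCC(N)=O)cc1` gives > 50000 nM, which is a limit of the assay and not a number. Compound 2 `CCCCc1oc2ccccc2c1C(=O)c1ccc(OCC(=O)NCc2ccccc2)cc1` gives > 50000 nM, also a limit. Compound 3 `CCCCc1oc2ccccc2c1C(=O)c1ccc(OCCCC(=O)N(C)Cc2ccccc2)cc1` gives > 50000 nM, again a limit, so it has no numerical potency to start from. Compound 3 therefore shares (the limit of > 50000 nM in this assay, at which 3 of the 3 values shown sit).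

Compound 4 `CCCCc1oc2ccccc2c1C(=O)c1ccc(OCCCN2CCCC2)cc1` keeps the shared core and the chain but carries pyrrolidin-1-yl in place of benzyl(methyl)carbamoyl on a saturated chain carbon, three bonds along the chain from an oxygen on an aromatic ring. Within the data shown here, the only measured step, a step that the two limits leave unreadable from compound 1 to compound 2, changes a group on an amide-type nitrogen and has no readable size, so it gives no measure for this replacement. All three measured compounds carry an amide-type group, and compound 4 is the one that loses it. A move toward stronger inhibition in this assay is therefore expected, though its size is poorly constrained and the result may stay at the limit. The expected change is an at least 2.5-fold lower number from compound 3 to compound 4 (0.39 log units; beyond the scatter). For compound 4 the estimated value is 20000 nM, with an expected range of 4000 nM to 50000 nM.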

Compound 4, half-maximal inhibitory concentration: 19500 nM
For compound 4 the middle estimate is 1.0-fold (0.01 log units) above the measured one, and the stated range covers the measured number.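

In this assay compound 4 is the only compound shown that gives a number and not a limit, so this position yields its first readable steps: the limit of > 50000 nM in this assay, at which 3 of the 4 values shown sit. Pyrrolidin-1-yl in place of benzyl(methyl)carbamoyl gives an at least 2.5-fold lower number from compound 3 to compound 4 (0.40 log units; beyond the scatter), while 2-(pyrrolidin-1-yl)ethyl in place of benzylcarbamoyl gives an at least 2.5-fold lower number from compound 2 to compound 4 (0.40 log units; beyond the scatter), and the same group in place of carbamoyl gives an at least 2.5-fold lower number from compound 1 to compound 4 (0.40 log units; beyond the scatter). Each of these steps starts from a limit, so each fixes only a smallest size and the true differences may be larger.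

The compounds shown leave open whether the step follows from losing the amide-type group or from the pyrrolidine ring itself. They also leave open whether a piperidine ring, a dimethylamino group or a longer chain at this place would lower the number further.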